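The compounds below may be only part of what the source reports. "The series", "measured", "known", "first", "only" and "open" are said of these compounds alone.

Measured in a functional assay on MCF7 cells (Homo sapiens) for antiproliferative activity, read by CCK-8 assay, with a stated time of 48 h; on this read-out higher numbers stand for weaker inhibition and lower numbers for stronger inhibition:
- compound 1 `O=C(/C=C/CNCCOc1ccc(Oc2c(-c3ccc(F)cc3)sc3cc(O)ccc23)cc1)N1CCCC1` gives 7610 nM
- compound 2 `CNC(=O)/C=C/CNCCOc1ccc(Oc2c(-c3ccc(F)cc3)sc3cc(O)ccc23)cc1` gives 16100 nM
- compound 3 `CN(C)C(=O)/C=C/CNCCOc1ccc(Oc2c(-c3ccc(F)cc3)sc3cc(O)ccc23)cc1` gives 13800 nM

Among the compounds with values here, only one step out of compound 1 passes the scatter: a 2.1-fold higher number from compound 1 to compound 2 (0.33 log units; beyond the scatter) is modest, whereas a 1.8-fold higher number from compound 1 to compound 3 (0.26 log units; within the scatter) stays within it, as does a 1.2-fold lower number from compound 2 to compound 3 (0.07 log units; within the scatter) on the amide nitrogen.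

Within the data shown here, the change to compound 4 `O=C(CCCNCCOc1ccc(Oc2c(-c3ccc(F)cc3)sc3cc(O)ccc23)cc1)N1CCC1` reads 2-((azetidin-1-yl)carbonyl)ethyl in place of 2-((pyrrolidin-1-yl)carbonyl)ethenyl on a saturated chain carbon bound to an amine nitrogen and has no direct precedent. Among the measured compounds shown here, the measured steps touch only the group on the carbonyl carbon, and no compound tests the saturated chain or the four-membered ring. Going by compound 2 at 16100 nM and compound 3 at 13800 nM, a small move to a higher number is expected, with a wide range.

The expected step is a 1.6-fold higher number from compound 1 to compound 4 (0.20 log units; within the scatter) as estimated here.

In this assay compound 4 is estimated at 12000 nM, within 5000 nM to 30000 nM.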

Compound 4, half-maximal inhibitory concentration: > 25000 nM
Compound 4 ended at the assay's limit; the forecaster's own chance of this, stated with the estimate: 10%; at least 2.0-fold (0.31 log units) between middle value and limit.
By their numbers in this assay, from the lowest: compounds 1, 3 and 2 (each within the scatter of the next, the first and the last beyond it). At a limit, above all of these: compound 4.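

In this assay compound 4 reads as a limit, not a number: the limit of > 25000 nM in this assay, at which 1 of the 4 values shown sits.

The saturated chain with the azetidine amide gives an at least 3.2-fold higher number from compound 1 to compound 4 (0.51 log units; beyond the scatter), so this double change in the chain and the ring on the carbonyl carries a cost beyond the scatter. Against the other two amides, an at least 1.8-fold higher number from compound 3 to compound 4 (0.25 log units; that floor lies within the scatter) and an at least 1.5-fold higher number from compound 2 to compound 4 (0.19 log units; that floor lies within the scatter) are floors within the scatter and set no order.

The compounds shown leave the loss of the double bond and the ring contraction unseparated. Also open, from the compounds shown here alone, is how a piperidin-1-yl amide or a carboxylic acid would read at this chain end.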